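This account rests on a few compounds, and the source may have more. Where it says the series, first, only, none or still open, it means among the compounds named here.

Working notes on a set of three measured compounds and one open position. Compound 1 `COc1ccc(/C=C/C(=O)c2ccccc2-c2ccc(F)cc2)cc1OC` gives 95 nM in a functional assay on HepG2 cells (Homo sapiens) for antiproliferative activity, read by sulforhodamine B assay, with a stated time of 48 h; on this read-out higher numbers stand for weaker inhibition and lower numbers for stronger inhibition. Compound 2 `COc1ccc(/C=C/C(=O)c2ccccc2-c2ccc(F)nc2)cc1OC` gives 1000 nM in this assay. The change from compound 1 to compound 2 is 6-fluoropyridin-3-yl in place of 4-fluorophenyl on an aromatic carbon and it produced an 11-fold higher number from compound 1 to compound 2 (1.02 log units; beyond the scatter). For the measured compounds named here, compound 3 `O=C(/C=C/c1ccccc1-c1ccc(F)cc1)c1cccc(O)c1` gives 4200 nM in this assay, the highest of the three numbers; the difference between its core and the core of compound 1 is not broken down here, and no step between compound 3 and either other compound is counted, so only the bare values stand side by side.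

Compound 4 `O=C(/C=C/c1ccccc1-c1ccc(F)nc1)c1cccc(O)c1` is not yet measured. Going by the values given here, it differs from compound 3 by 6-fluoropyridin-3-yl in place of 4-fluorophenyl on an aromatic carbon, the same change, at a place described in the same words, as the one from compound 1 to compound 2. The step from compound 3 to compound 4 in this assay is expected to be a 7.1-fold higher number from compound 3 to compound 4 (0.85 log units; beyond the scatter). Among the compounds with values here, that expectation rests on the single earlier instance an 11-fold higher number from compound 1 to compound 2 (1.02 log units; beyond the scatter). The core of compound 3 differs from the core of compound 1, and the change has been seen only once, so the expectation is held loosely. Compound 4 is estimated at 30000 nM, within a range from 8000 nM to 100000 nM.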

Compound 4, half-maximal inhibitory concentration: 6400 nM
For compound 4 the middle estimate is 4.7-fold (0.67 log units) above the measured one; measured number below the stated range.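

In this assay, 6-fluoropyridin-3-yl in place of 4-fluorophenyl on an aromatic carbon gives a 1.5-fold higher number from compound 3 to compound 4 (0.18 log units; within the scatter), so on this core the change leaves the number within the scatter. The large step seen on the core of compound 1 therefore did not carry over, and the two instances disagree: the same change on two cores in this assay, an 11-fold higher number (1.02 log units; beyond the scatter) from compound 1 to compound 2 and a 1.5-fold higher number (0.18 log units; within the scatter) from compound 3 to compound 4, 6.9-fold (0.84 log units) apart, beyond the scatter of two such steps. For these two cores, the size of the step depends on the core, but two instances give no general rule for the series and do not show which feature of the cores matters.

On these data alone, it remains open which part of the difference between the cores governs the size of the step, and a compound with a single hydroxyl in place of the two methoxy groups on the core of compound 1 would help to separate those parts. Also open, as far as these compounds go, is how a pyridine carrying an amine in place of the fluorine would behave at this position on each core.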